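A few compounds are considered here, and "the series" means these few. Any claim that something is new, unique, unknown or untested is made for them only; others in the source may bear on it.

Measured compounds:
compound 1 `CCCCOC(=O)NS(=O)(=O)c1ccc(CCC)cc1-c1ccc(Cn2cnc3ccccc32)cc1` — 29 nM
compound 2 `CCCCOC(=O)NS(=O)(=O)c1ccc(CCC)cc1-c1ccc(Cn2c(C3CCCCC3)nc3ccccc32)cc1` — 130 nM

In an assay on membranes from HEK293 cells for displacement of a labelled ligand from Type-2 angiotensin II receptor (Homo sapiens), read by radioligand binding (a higher number here means a weaker inhibitor, a lower number a stronger inhibitor), compound 2 gives the higher of the two numbers; the step of a 4.5-fold higher number from compound 1 to compound 2 (0.65 log units; beyond the scatter) shows a modest loss. Compound 3 `CCCCOC(=O)NS(=O)(=O)c1ccc(CCC)cc1-c1ccc(Cn2c(CCCC)nc3ccccc32)cc1` differs from compound 2 by butyl in place of cyclohexyl on an aromatic carbon. For the measured compounds named here, only that one step bears on this change, and it shows that a large group at this place weakens binding in this assay. Butyl is smaller than cyclohexyl, so a modest gain is expected, a 2.2-fold lower number from compound 2 to compound 3 (0.34 log units; beyond the scatter), landing between the two measured values. Compound 3 is therefore estimated at 60 nM in this assay, within 25 nM to 150 nM.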

Compound 3, inhibition constant: 9.2 nM
Compound 3: the middle estimate sits 6.5-fold (0.81 log units) above what was measured; measured number outside the range, below it.
By their numbers in this assay, from the lowest: compound 3; then compound 1; then compound 2.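

In this assay, a group at this place does not in itself weaken binding: butyl in place of hydrogen gives a 3.2-fold lower number from compound 1 to compound 3 (0.50 log units; beyond the scatter), the opposite direction to cyclohexyl. Which group sits here therefore matters, as the change to butyl gives a 14-fold lower number from compound 2 to compound 3 (1.15 log units; beyond the scatter). Nothing available explains this difference between the two groups.

Butyl differs from cyclohexyl both in size and in having no ring, so these compounds cannot separate the two. As far as these compounds go, how propyl, a longer chain such as hexyl, or an amine would behave here remains open.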